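The compounds below may be only part of what the source reports. "The series", "measured", "known", "first", "only" and "open" are said of these compounds alone.

Working notes on the series. For the measured compounds named here, compound 2 `CCCCCCCCCCCCCCC1(C(=O)OC)CO1` stands at the lower of the two numbers measured so far: in a functional assay for inhibition, with Rattus norvegicus as the target (a higher number here means that more compound is needed for the effect, a lower number that less compound is needed), compound 2 gives 0.1 uM, while compound 1 `CCCCCCCCCCCC1(C(=O)OC)CO1` gives 2.5 uM in this assay. Going by the values given here, the one step between measured compounds is a 25-fold lower number from compound 1 to compound 2 (1.40 log units; beyond the scatter), the change being propyl in place of hydrogen on a saturated chain carbon, ten or more bonds along the chain from a saturated ring carbon.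

Compound 3 `CCCCCCCCCCC1(C(=O)OC)CO1` has not been measured. It differs from compound 2 by hydrogen in place of butyl on a saturated chain carbon, ten or more bonds along the chain from a saturated ring carbon. This is the reverse of the measured step at the same place, carried further: where propyl entered going from compound 1 to compound 2, here butyl leaves from compound 2. Among the compounds with values here, only the step from compound 1 to compound 2 bears on it, and it was large, so a large step in this assay toward a higher number is expected, somewhat exceeding that step in size because of a 25-fold lower number from compound 1 to compound 2 (1.40 log units; beyond the scatter) and the fact that more chain is removed than was added there. The number for compound 3 is estimated at 7 uM, in the range 2 uM to 30 uM, which means an expected step of a 70-fold higher number from compound 2 to compound 3 (1.85 log units; beyond the scatter).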

Compound 3, minimum effective concentration: 0.5 uM
For compound 3 the middle estimate is 14-fold (1.15 log units) above the measured one, and the stated range ends above it.
By their numbers in this assay, from the lowest: compound 2; then compound 3; then compound 1.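

The chain at this place does not act in one direction in this assay: hydrogen in place of butyl gives a 5.0-fold higher number from compound 2 to compound 3 (0.70 log units; beyond the scatter) and so reverses only part of the earlier gain, while hydrogen in place of methyl gives a 5.0-fold lower number from compound 1 to compound 3 (0.70 log units; beyond the scatter) and thus moves the number the other way. Compound 3, with the shortest chain of the three, therefore stands between compound 2 and compound 1, and compound 1, with its intermediate chain, has the highest number. A steady relation between chain length and the number is thus ruled out across these compounds, with compound 1 as the one that goes against it, and the single earlier step had not shown this. No measurement at hand accounts for this reversal.

The compounds shown leave open whether the number keeps falling or turns upward with a longer chain than that of compound 2, and whether the rise at compound 1 is a single irregular point or part of a wider pattern among neighbouring chains. They also leave open how a hydroxyl, an amine or a carboxylic acid would behave in place of hydrogen on a saturated chain carbon at this place.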